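A few compounds are considered here, and "the series" means these few. Any claim that something is new, unique, unknown or untested is made for them only; others in the source may bear on it.

Measured compounds:

Compound 1, `COC1=C(C)C(=O)/C(=C(O)/C=C/c2c(C)cccc2C)C(=O)C1(C)C`: 8.3 ug/mL
Compound 2, `COC1=C(C)C(=O)/C(=C(O)/C=C/c2c(C)cc(C)cc2C)C(=O)C1(C)C`: 8 ug/mL
Compound 3, `CCC1=C(OC)C(CC)(CC)C(=O)C(C(=O)/C=C/c2ccccc2)=C1O`: 3.4 ug/mL

All three were tested in a functional assay on A549 cells (Homo sapiens) for cytotoxicity; a higher number here means that more compound is needed for the effect, a lower number that less compound is needed. Compound 1 and compound 2 share one core and differ by methyl in place of hydrogen on an aromatic carbon, and the step of a 1.0-fold lower number from compound 1 to compound 2 (0.02 log units; within the scatter) sits within the scatter, so the two numbers cannot be told apart. Compound 3 carries a different core; the difference between the two cores is not broken down here. In this assay compound 3 gives 3.4 ug/mL, the lowest number of the three, with both other compounds standing beyond the scatter above it.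

The unmeasured compound 4, `CCC1=C(OC)C(CC)(CC)C(=O)C(C(=O)/C=C/c2ccc(C)cc2)=C1O`, is built on the core of compound 3 and differs from it by methyl in place of hydrogen on an aromatic carbon. This is the same kind of change as that from compound 1 to compound 2, but not the same: in compound 2 the entering methyl sits meta to two methyl groups and para to a large group, whereas in compound 4 it sits para to a large group with no further methyl groups on that ring. For the measured compounds named here, the only measured example, compound 1 to compound 2, produced no step beyond the scatter, and on that single pair the expectation rests. Compound 4 is therefore expected to stay close to compound 3, with an estimated step of a 1.0-fold higher number from compound 3 to compound 4 (0.01 log units; within the scatter) because a 1.0-fold lower number from compound 1 to compound 2 (0.02 log units; within the scatter) was flat. Compound 4 is estimated at 3.5 ug/mL, expected to lie between 1.8 ug/mL and 7 ug/mL.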

Compound 4, concentration for half-maximal effect: 4.6 ug/mL
Estimate against measurement, compound 4: 1.3-fold (0.12 log units) below; the range from low to high includes it.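

On the second core, methyl in place of hydrogen on an aromatic carbon, here para to a large group, gives a 1.4-fold higher number from compound 3 to compound 4 (0.13 log units; within the scatter), so in this assay the two numbers cannot be told apart. Set beside the earlier pair, the change reads alike on both cores: the same change on two cores in this assay, a 1.0-fold lower number (0.02 log units; within the scatter) from compound 1 to compound 2 and a 1.4-fold higher number (0.13 log units; within the scatter) from compound 3 to compound 4, 1.4-fold (0.15 log units) apart, within the scatter of two such steps This shows that across these two pairs the added methyl leaves the number in this assay flat on either core, with no detectable difference between the cores, but it rests on only two pairs, and the rings receiving the methyl are not alike, so it does not show that the change would stay flat on a further core or in another setting.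

The aromatic rings shown carry only hydrogen or methyl, so it remains open how an amine, a carboxylic acid or a chlorine on that ring would read in this assay, and whether a longer chain such as propyl in place of the methyl would stay as flat. The comparison also leaves open what separates the two cores themselves, as no pair shown differs in the core alone.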